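Replacing pyrrolidin-1-yl with 2,6-dimethylmorpholin-4-yl

This account rests on a few compounds, and the source may have more. Where it says the series, first, only, none or still open, it means among the compounds named here.

Values in a functional assay on A549 cells (Homo sapiens) for inhibition, read by MTT assay, with a stated time of 48 h (a lower number here means a stronger inhibitor, a higher number a weaker inhibitor), follow.
Compound 1 `Cn1c(/C=C2\SC(=O)N(CC(=O)Nc3cc(C(C)(C)C)on3)C2=O)nc2ccccc21` gives 15300 nM
Compound 2 `Cn1c(/C=C2\SC(=O)N(CC(=O)N3CCCC3)C2=O)nc2ccccc21` gives > 50000 nM as a limit
Compound 3 `CC1CN(C(=O)CN2C(=O)S/C(=C\c3nc4ccccc4n3C)C2=O)CC(C)O1` awaits measurement

Compound 2 has no number, and the limit of > 50000 nM in this assay, at which 1 of the 2 values shown sits, is all that marks its standing. Going on to compound 3 brings 2,6-dimethylmorpholin-4-yl in place of pyrrolidin-1-yl on a carbonyl carbon as the only change. Within the data shown here, the one measured step on this carbonyl carbon is an at least 3.2-fold higher number from compound 1 to compound 2 (0.51 log units; beyond the scatter) and it gives only a bound on size. Neither compound 1 nor compound 2 carries 2,6-dimethylmorpholin-4-yl, so that step sets no direction here. For compound 2 the value > 50000 nM remains a limit and is the sole anchor. No step beyond the scatter is expected in this assay and another limit is quite possible. The expected change is a number no higher from compound 2 to compound 3 (the limit leaves the size open) at most a small one. Compound 3 is estimated at 50000 nM with an expected range from 20000 nM to 100000 nM in all.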

Compound 3, half-maximal inhibitory concentration: 29400 nM
Compound 3: middle estimate off by 1.7-fold (0.23 log units), on the high side; the range from low to high includes it.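

In this assay, the change at this carbonyl carbon gives an at least 1.7-fold lower number from compound 2 to compound 3 (0.23 log units; that floor lies within the scatter), and compound 3 carries a measured number where the earlier pyrrolidin-1-yl amide did not. As far as these compounds go, compound 2 remains a limit, so the true size of this step stays open because of its standing: the limit of > 50000 nM in this assay, at which 1 of the 3 values shown sits. The comparison with the amide of compound 1 gives a 1.9-fold higher number from compound 1 to compound 3 (0.28 log units; within the scatter), so 2,6-dimethylmorpholin-4-yl, with 0 hydrogen-bond donors, and (5-(tert-butyl)-1,2-oxazol-3-yl)amino cannot be told apart here.

The change to compound 3 alters ring size, adds a ring oxygen and adds two methyl groups at once, and the compounds shown do not separate these. Plain morpholin-4-yl and piperidin-1-yl on this carbonyl carbon would address that question.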